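The source may report more compounds than this note shows. Statements on the series, on what has been measured and on what is new or still open speak of the compounds shown alone.

Compound 1 `CCN1CCN(c2cccc3c2C(=O)N([C@H](CCCNS(=O)(=O)c2cn(C)c(C)n2)c2ccc(OC)c(OC)c2)C3=O)CC1`: 810 nM
Compound 2 `CCN1CCN(c2cccc3c2CN([C@H](CCCNC(=O)c2c(C)n[nH]c2C)c2ccc(OC)c(OC)c2)C3=O)CC1`: 130 nM
Compound 3 `COc1ccc([C@@H](CCCN(C)S(=O)(=O)c2cccs2)N2Cc3c(cccc3N3CCN(C4CC4)CC3)C2=O)cc1OC`: 1200 nM

In a functional assay on RMS13 cells for antagonist activity at Urotensin-2 receptor (Homo sapiens), read by FLIPR and calcium flux, with a stated time of 1 h (on this read-out higher numbers stand for weaker inhibition and lower numbers for stronger inhibition), compound 2 gives the lowest number of the three, and the numbers of compound 1 and compound 3 both lie beyond the usual scatter above it, so compound 2 is the most potent of the measured set. Compound 4 `CCN1CCN(c2cccc3c2CN([C@H](CCCNc2cncc(OC)n2)c2ccc(OC)c(OC)c2)C3=O)CC1` is built from compound 2 by a single change: 6-methoxypyrazin-2-yl in place of (3,5-dimethyl-1H-pyrazol-4-yl)carbonyl on an amine nitrogen. Among the compounds with values here, no pair of measured compounds shows this change, so its effect can only be guessed. Because compound 2 gives 130 nM, the author expects compound 4 to stay in the same region, with a modest loss of potency that may exceed the scatter, a step of a 2.3-fold higher number from compound 2 to compound 4 (0.36 log units; beyond the scatter). For compound 4 the estimate is 300 nM, within 80 nM to 1100 nM.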

Compound 4, half-maximal inhibitory concentration: 62 nM
The estimate for compound 4 lay 4.8-fold (0.68 log units) above the measured number, outside the stated range (below it).
By their numbers in this assay, from the lowest: compound 4; then compound 2; then compounds 1 and 3 (each within the scatter of the next).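

In this assay, 6-methoxypyrazin-2-yl in place of (3,5-dimethyl-1H-pyrazol-4-yl)carbonyl on the amine nitrogen gives a 2.1-fold lower number from compound 2 to compound 4 (0.32 log units; beyond the scatter), a modest gain. This position therefore does not depend on the carbonyl or on a hydrogen-bond donor in the group it carries, since a six-membered aromatic ring with neither retains the potency and adds to it. Nothing measured here explains the gain.

From the compounds shown here alone, the role of the methoxy group remains open, as does how an unsubstituted pyrazin-2-yl, a pyridin-2-yl or an ethoxy analogue would read on this amine nitrogen.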